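Methyl for Chloro on the Core of Compound 2

A few compounds are considered here, and "the series" means these few. Any claim that something is new, unique, unknown or untested is made for them only; others in the source may bear on it.

Measured so far:
compound 1, `O=C(Cc1cccnc1)c1cc2cc(-c3ccccc3)ccc2[nH]1`, in an in vitro assay on P815B cells for inhibition of Indoleamine 2,3-dioxygenase 1 (Mus musculus), tested at 20 uM (on this read-out higher numbers stand for more inhibition at the one concentration tested (going by the name of the read-out) and lower numbers for less inhibition), gives "not active" (no number reported), a result with no number.
compound 2, `O=C(Cc1cccnc1)c1cc2cc(Cl)ccc2[nH]1`, in this assay gives 24%.

Compound 2 thus carries the only number shown; compound 1 stands beside it without one. Compound 3, `Cc1ccc2[nH]c(C(=O)Cc3cccnc3)cc2c1`, has not been measured. It differs from compound 2 in one place: methyl in place of chloro on an aromatic carbon. Among the compounds with values here, no step between two measured compounds exists, so the size of this change in this assay is not known from the data. Compound 3 is expected to stay close to compound 2, a shift of a number 6 percentage points lower from compound 2 to compound 3 (within the scatter) within the scatter. Compound 3 is estimated at 18%, between 0% and 40%.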

Compound 3, a percentage reported as inhibition, at one concentration (the size of the read-out at that concentration, not a potency): 21%
Compound 3: middle estimate off by 3 percentage points, on the low side, within the range that was stated.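

With methyl in place of chloro on this aromatic carbon, this assay gives a number 3 percentage points lower from compound 2 to compound 3 (within the scatter). Within the data shown here, this is the first step between two compounds with numbers, and it shows that these two groups of one heavy atom cannot be told apart on this read-out at this position. No measurement here offers an explanation for that result. Still open, as far as these compounds go, is how an amine, a methoxy group or a carboxylic acid would read at this carbon. From the compounds shown here alone, a longer chain, such as ethyl or propyl, is equally open.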